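Swapping ethoxy for chloro on the coumarin-type ring

The source may hold more compounds than are shown below. What is called first, only, known or untested is meant among the compounds shown, and "the series" means these compounds.

Measured compounds:
- compound 1 `COc1ccc(/C=C/c2cc(OC)cc(OC)c2/C=C/C(=O)c2cc3cc(Br)cc(OC)c3oc2=O)cc1`: in an assay on isolated protein for inhibition of Amine oxidase [flavin-containing] B (Homo sapiens), read by fluorescence, with a stated time of 15 min (on this read-out lower numbers stand for stronger inhibition and higher numbers for weaker inhibition), compound 1 gives > 60000 nM, which is a limit of the assay, not a number.
- compound 2 `CCOc1ccc2cc(C(=O)/C=C/c3c(/C=C/c4ccc(OC)cc4)cc(OC)cc3OC)c(=O)oc2c1`: in this assay compound 2 gives 48100 nM.

For the measured compounds named here, compound 2 holds the only true number in this set; the other entry, that of compound 1, sits at the limit of > 60000 nM in this assay, at which 1 of the 2 values shown sits. Within these two entries compound 2 is therefore the sole fixed point, and it is a weak inhibitor by any standard.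

Compound 3 `COc1ccc(/C=C/c2cc(OC)cc(OC)c2/C=C/C(=O)c2cc3ccc(Cl)cc3oc2=O)cc1` has not yet been measured. It differs from compound 2 in one place: chloro in place of ethoxy on an aromatic carbon. The rest of the molecule, the long chain of double bonds and the methoxy-bearing rings, stays the same.

Going by the values given here, no pair of measured compounds isolates this particular swap, so the size of the step cannot be read off from the data. Compound 1, which carries bromo together with methoxy on that same ring, reaches only the limit, which hints that a halogen there does not rescue potency. The expectation for compound 3 is a step of a 1.1-fold higher number from compound 2 to compound 3 (0.06 log units; within the scatter) in this assay, at most a small shift in either direction and likely within the scatter. Compound 3 is thus estimated at 55000 nM, with a range from 20000 nM to 150000 nM, and a real chance that the assay again reports only a limit.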

Compound 3, half-maximal inhibitory concentration: 7360 nM
Compound 3: middle estimate off by 7.5-fold (0.87 log units), on the high side; the whole stated range lies above it.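

In this assay, the aromatic carbon that carries the ethoxy group in compound 2 proves to matter: chloro in place of ethoxy gives a 6.5-fold lower number from compound 2 to compound 3 (0.82 log units; beyond the scatter), a modest step but one beyond the usual scatter. The earlier entries could not show this, since they offered one number and one limit, and so gave no way of telling whether a change at this place moves the read-out at all. Compound 1 remains a limit of the assay and not a number, and steps involving it cannot be read: the limit of > 60000 nM in this assay, at which 1 of the 3 values shown sits.

What this single pair leaves open is whether the lower number comes from losing the ethoxy group, with its 3 heavy atoms and its hydrogen-bond acceptor, or from gaining the chlorine itself. A plain hydrogen or an amine on this same aromatic carbon would help separate those two readings, and would show how much further the number can move from this one place on the shared core.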